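The source may report more compounds than this note shows. Statements on the series, on what has been measured and on what is new or still open speak of the compounds shown alone.

Measured so far:
compound 1 `COc1cc(-c2nnc(SCC(=O)c3ccc(Cl)cc3)n2N)cc(OC)c1OC`: > 100000 nM
compound 2 `COc1cc(-c2nnc(SCC(=O)c3ccc(C)cc3)n2N)cc(OC)c1OC`: > 100000 nM

Both figures come from a functional assay on HepG2 cells (Homo sapiens) for antiproliferative activity, read by MTT assay, with a stated time of 48 h; a higher number here means a weaker inhibitor, a lower number a stronger inhibitor. The figure for compound 1 is a limit of the assay, not a measured number. The figure for compound 2 is likewise a limit. Among the compounds with values here, both therefore sit at the limit of > 100000 nM in this assay, at which 2 of the 2 values shown sit, and the single step between measured compounds, a step that the two limits leave unreadable from compound 1 to compound 2, has no readable size; both of its ends are limits. Where compound 2 stands on the numbers is thus known only in one direction: it gave no measurable inhibition within the assay window.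

Compound 3 is `COc1cc(-c2nnc(SCC(=O)c3ccc(C(F)(F)F)cc3)n2N)cc(OC)c1OC`. It differs from compound 2 by trifluoromethyl in place of methyl on an aromatic carbon. Within the data shown here, the only measured step touching this position is the one from compound 1 to compound 2, and it gives no size, so no pattern can be drawn from it. Among the measured compounds shown here, nothing among the measured compounds points to a gain in potency from such a swap. The expected step is a number no higher from compound 2 to compound 3 (the limit leaves the size open), nothing beyond the scatter, and compound 3 is expected most likely to return a limit again. Compound 3 is estimated at 100000 nM, in the range 30000 nM to 300000 nM.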

Compound 3, half-maximal inhibitory concentration: > 100000 nM
Compound 3 ended at the assay's limit; the forecaster's own chance of this, stated with the estimate: 80%; the middle value sits exactly at the limit.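

The value for compound 3 is a limit of the assay, as are those for compound 1 and compound 2, so no step among these three compounds can be read: the limit of > 100000 nM in this assay, at which 3 of the 3 values shown sit.

The compounds shown leave open how chloro, methyl and trifluoromethyl compare in this assay, and which change to the shared core would give a measurable value.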